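The source may hold more compounds than are shown below. What is called first, only, known or untested is meant among the compounds shown, and "the series" means these compounds.

In a functional assay on DU-145 cells (Homo sapiens) for cytotoxicity, read by trypan blue exclusion, with a stated time of 96 h (on this read-out higher numbers stand for weaker inhibition and lower numbers for stronger inhibition), compound 1 `COc1cc(OC)c(/C=C/S(=O)(=O)Nc2ccc(OC)c([N+](=O)[O-])c2)c(OC)c1` gives 2500 nM, while compound 2 `COc1cc(OC)c(/C=C/S(=O)(=O)Nc2ccc(OC)c(N)c2)c(OC)c1` gives 5 nM, the lower of the two numbers and so the stronger inhibition. Compound 3 `COC(=O)C(C)(C)Nc1cc(NS(=O)(=O)/C=C/c2c(OC)cc(OC)cc2OC)ccc1OC` differs from compound 2 by one change, 1-(methoxycarbonyl)-1-methylethyl in place of hydrogen on a nitrogen on an aromatic ring. Among the measured compounds shown here, only one measured step bears on this change. Amino in place of nitro gave a 500-fold lower number from compound 1 to compound 2 (2.70 log units; beyond the scatter), a large step that created the very amino group now being altered. For the measured compounds named here, it shows that this assay can respond strongly to a change at this spot, but no measured compound carries a substituent on that nitrogen, so the size of the next step remains uncertain. A clear move towards weaker inhibition is expected, probably smaller than that earlier step. The expected change is a 20-fold higher number from compound 2 to compound 3 (1.30 log units; beyond the scatter). For compound 3 the estimated value is 100 nM, with an expected range from 10 nM to 1000 nM.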

Compound 3, half-maximal inhibitory concentration: 200 nM
Estimate against measurement, compound 3: 2.0-fold (0.30 log units) below, and the stated range covers the measured number.
By their numbers in this assay, from the lowest: compound 2; then compound 3; then compound 1.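

Substitution on this nitrogen carries a cost: in this assay, placing 1-(methoxycarbonyl)-1-methylethyl on it in place of hydrogen gives a 40-fold higher number from compound 2 to compound 3 (1.60 log units; beyond the scatter). Yet the substituted amine still reads better than the nitro group, with a 13-fold lower number from compound 1 to compound 3 (1.10 log units; beyond the scatter), so only part of the gain from the free amino group is lost. Why the numbers move this way is not settled by anything available here.

From the compounds shown here alone, it remains open whether the loss follows from any substituent on this nitrogen, or specifically from the methoxycarbonyl part or the methyl groups of this one. A single methyl on the nitrogen, or a carboxylic acid in place of the methyl ester, would help to separate these possibilities.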